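Swapping the sulfonate ester for an acetate: cytotoxicity

The source may hold more compounds than are shown below. What is called first, only, known or untested is meant among the compounds shown, and "the series" means these compounds.

Compound 1 `O=c1cc(N2CCN(CC3CCC(OS(=O)(=O)c4cccnc4)CC3)CC2)sc2c([N+](=O)[O-])cc(C(F)(F)F)cc12` in an ADME assay on Vero cells (Chlorocebus sabaeus) for cytotoxicity, read by MTT assay, with a stated time of 48 h (on this read-out higher numbers stand for weaker inhibition and lower numbers for stronger inhibition), gives > 64 ug/mL, which is a limit of the assay and not a number.
Compound 2 `C=CC(=O)OC1CCC(CN2CCN(c3cc(=O)c4cc(C(F)(F)F)cc([N+](=O)[O-])c4s3)CC2)CC1` in this assay gives > 64 ug/mL, again only a limit.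
Compound 3 `O=C(OC1CCC(CN2CCN(c3cc(=O)c4cc(C(F)(F)F)cc([N+](=O)[O-])c4s3)CC2)CC1)c1cccc(C(F)(F)F)c1` in this assay gives > 64 ug/mL, once more a limit.

Compound 1 therefore stands nowhere on a scale of numbers: it sits at the limit, and so do the other two compounds measured, as the limit of > 64 ug/mL in this assay, at which 3 of the 3 values shown sit, records. The three compounds share one core and differ only in the group attached through an oxygen on a saturated carbon. Every value is a limit. The steps a step that the two limits leave unreadable from compound 1 to compound 2, a step that the two limits leave unreadable from compound 1 to compound 3 and a step that the two limits leave unreadable from compound 2 to compound 3 cannot be read in size or direction.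

Compound 4 `CC(=O)OC1CCC(CN2CCN(c3cc(=O)c4cc(C(F)(F)F)cc([N+](=O)[O-])c4s3)CC2)CC1` makes a change of the same kind at the same place: acetyl in place of (pyridin-3-yl)sulfonyl on an oxygen on a saturated carbon. Going by the values given here, the measured steps that bear on it are all unreadable, and the only evidence is that all three analogues sit at the limit (the limit of > 64 ug/mL in this assay, at which 3 of the 3 values shown sit). No step beyond the scatter can be foreseen; the expectation is that the step that the limit leaves unreadable from compound 1 to compound 4 again ends at the limit. Compound 4 is thus estimated at 80 ug/mL, with a range from 40 ug/mL to 160 ug/mL, most likely reported only as a limit.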

Compound 4, half-maximal inhibitory concentration: > 64 ug/mL
Compound 4 was reported as a limit; the forecaster's own chance of this, stated with the estimate: 85%; the middle value lies beyond the limit too.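

In this assay compound 4 gives > 64 ug/mL, which is a limit of the assay and not a number. Its steps to compound 1, compound 2 and compound 3 therefore cannot be read in size or direction: the limit of > 64 ug/mL in this assay, at which 4 of the 4 values shown sit.

The compounds shown leave open whether the group on the oxygen affects cytotoxicity at all, and at what concentration any of these compounds would reach half-maximal inhibition.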